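Compound 2 to compound 3: fluoro in place of hydrogen

This account rests on a few compounds, and the source may have more. Where it says the series, first, only, none or still open, it means among the compounds named here.

Compound 2 `CN1CCC(n2cc(S(=O)(=O)c3ccccc3)c3cccnc32)C1` holds the highest of the two numbers in a functional assay on HeLa cells for agonist activity at 5-hydroxytryptamine receptor 6 (Homo sapiens), read by cAMP accumulation and immunoassay; on this read-out lower numbers stand for smaller maximal responses and higher numbers for larger maximal responses: compound 2 gives 61%. Going by the values given here, its nearest neighbour, compound 1 `O=S(=O)(c1cccc(F)c1)c1cn(C2CCNC2)c2ncccc12`, gives 44%, a lower number and beyond the usual scatter, but compound 1 differs from compound 2 in more than one place, so no single step is defined between them.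

Compound 3 `CN1CCC(n2cc(S(=O)(=O)c3cccc(F)c3)c3cccnc32)C1` differs from compound 2 by fluoro in place of hydrogen on an aromatic carbon. Among the compounds with values here, no pair of measured compounds isolates this change, so the only guide is the lower number of compound 1, which carries the same fluoro. The step is expected to be small, within the scatter and leaning downward, as a number 6 percentage points lower from compound 2 to compound 3 (within the scatter). Compound 3 is estimated at 55%, with a range from 40% to 70%.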

Compound 3, largest response reached (Emax), in percent of the reference or control that the assay uses: 54%
Estimate against measurement, compound 3: 1 percentage points above; the measured number falls inside the stated range.
By their numbers in this assay, from the lowest: compounds 1, 3 and 2 (each within the scatter of the next, the first and the last beyond it).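

In this assay, fluoro in place of hydrogen on this aromatic carbon gives a number 7 percentage points lower from compound 2 to compound 3 (within the scatter) and so, with the ring amine methylated, phenyl to 3-fluorophenyl does not stand clear of the scatter. With the fluoro held constant, methyl in place of hydrogen on the amine nitrogen in the ring gives a number 10 percentage points higher from compound 1 to compound 3 (within the scatter) and is likewise not separated from it. No measurement at hand explains the size of either step. Still open, going by these compounds, are other groups at this aromatic carbon, such as chloro or methoxy, and a longer chain, such as ethyl, on the ring nitrogen.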